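A few compounds are considered here, and "the series" means these few. Any claim that something is new, unique, unknown or untested is made for them only; others in the source may bear on it.

Measured so far in a functional assay on HeLa cells (Homo sapiens) for cytotoxicity, read by MTT assay, with a stated time of 24 h; on this read-out higher numbers stand for weaker inhibition and lower numbers for stronger inhibition:
compound 1 `Nc1ccc2sc(NC(=S)NC(=O)c3ccc([N+](=O)[O-])cc3)nc2c1` — 63100 nM
compound 2 `O=C(NC(=S)Nc1nc2cc(Br)ccc2s1)c1cccs1` — 46500 nM
compound 3 `CCCCC(=O)NC(=S)Nc1nc2cc(Br)ccc2s1` — 60200 nM

Compound 2 holds the lowest of the three numbers, but the gap to compound 3 (a 1.3-fold higher number from compound 2 to compound 3 (0.11 log units; within the scatter)) lies within the scatter, and so does the gap to compound 1; no ranking among the three follows. Compound 4 `O=C(NC(=S)Nc1nc2cc([N+](=O)[O-])ccc2s1)c1cccs1` is unmeasured. It differs from compound 2 by nitro in place of bromo on an aromatic carbon. Among the measured compounds shown here, no measured step alters this ring substituent; the one step known, from compound 2 to compound 3, changes only the acyl group and stays within the scatter. The values of compound 1 and compound 2 also lie within the scatter of each other. No step beyond the scatter is therefore expected in this assay. Compound 4 is estimated at 50000 nM, range 25000 nM to 100000 nM, a step of a 1.1-fold higher number from compound 2 to compound 4 (0.03 log units; within the scatter).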

Compound 4, half-maximal inhibitory concentration: 72600 nM
The estimate for compound 4 lay 1.5-fold (0.16 log units) below the measured number; low and high end bracket the measured number.
By their numbers in this assay, from the lowest: compounds 2, 3, 1 and 4 (each within the scatter of the next).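

In this assay, nitro in place of bromo on an aromatic carbon gives a 1.6-fold higher number from compound 2 to compound 4 (0.19 log units; within the scatter). Among the compounds shown here, the ring substituent, which no earlier step touched, thus joins the acyl group as a place where a single change stays within the scatter. No evidence bears on this result.

Still open, on these data alone, is whether a carboxylic acid or a methoxy group on this aromatic carbon would give a step beyond the scatter. The same holds for a longer chain in place of butyl on the carbonyl carbon.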